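Biaryl dichloroacetamides: phenyl in place of methoxycarbonyl

A few compounds are considered here, and "the series" means these few. Any claim that something is new, unique, unknown or untested is made for them only; others in the source may bear on it.

Measured compounds:
Compound 1 `O=C(Nc1cccc(-c2ccc(F)cc2)c1)C(Cl)Cl`: in a functional assay on NCI-H460 cells (Homo sapiens) for cytotoxicity, read by MTT assay, with a stated time of 68 h (on this read-out lower numbers stand for stronger inhibition and higher numbers for weaker inhibition), compound 1 gives > 50000 nM, which is a limit of the assay and not a number.
Compound 2 `COC(=O)c1ccc(-c2cccc(NC(=O)C(Cl)Cl)c2)cc1`: in this assay compound 2 gives > 50000 nM, again only a limit.
Compound 3 `Nc1cccc(-c2cccc(NC(=O)C(Cl)Cl)c2)c1`: in this assay compound 3 gives > 50000 nM, also a limit.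

Compound 2 therefore stands nowhere in particular on the numbers shown: it sits at the limit of > 50000 nM in this assay, at which 3 of the 3 values shown sit, together with the other two. Within the data shown here, the only single-point step between measured compounds, a step that the two limits leave unreadable from compound 1 to compound 2, is unreadable, as both ends are limits. Among the measured compounds shown here, no measured step carries any readable size.

The change from compound 2 to compound 4 `O=C(Nc1cccc(-c2ccc(-c3ccccc3)cc2)c1)C(Cl)Cl` is phenyl in place of methoxycarbonyl on an aromatic carbon. For the measured compounds named here, no measured step bears on this change. With every value in the series at the limit, and nothing to set a direction, no step beyond the usual scatter can be expected in this assay; the expectation is that compound 4 also reports only a limit.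

Compound 4 is estimated at 50000 nM, with an expected range from 20000 nM to 100000 nM. The step this estimate implies, a number no higher from compound 2 to compound 4 (the limit leaves the size open), is expected to be no more than scatter.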

Compound 4, half-maximal inhibitory concentration: 10900 nM
Beside the measured number, compound 4's estimate is 4.6-fold (0.66 log units) above it, and the stated range ends above it.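

Among these compounds, at the position para to a large group, phenyl gives the only readable number of the series in this assay, with an at least 4.5-fold lower number from compound 2 to compound 4 (0.66 log units; beyond the scatter), and phenyl in place of fluoro gives an at least 4.5-fold lower number from compound 1 to compound 4 (0.66 log units; beyond the scatter). Both steps start from values that are limits and not numbers, so each gives only a least size, and the step between compound 1 and compound 2, with a limit at both ends, cannot be read. Methoxycarbonyl and fluoro thus leave the series at the limit, and compound 4 alone comes off it: the limit of > 50000 nM in this assay, at which 3 of the 4 values shown sit.

On these data alone, whether an aromatic ring is needed at this position stays open, as a cyclohexyl or a pyridyl ring there would test. How far the series can go below the value of compound 4 also stays open, since the compounds shown hold only this one readable number.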